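The source may hold more compounds than are shown below. What is called first, only, known or untested is meant among the compounds shown, and "the series" means these compounds.

Measured so far:
- compound 1 `CC(C)(C)n1ncc(OCc2nnc(-c3ccccc3Cl)o2)c(Cl)c1=O`: 3.19
- compound 2 `CC(C)(C)n1ncc(OCc2nnc(-c3c(F)cccc3F)o2)c(Cl)c1=O`: 2.75

In a physicochemical assay for lipophilicity (on this read-out lower numbers stand for lower lipophilicity and higher numbers for higher lipophilicity), compound 1 stands highest of the two numbers; compound 2 is the nearest and sits a number 0.44 log units lower from compound 1 to compound 2 (beyond the scatter). Compound 3 `Cc1cccc(-c2nnc(COc3cnn(C(C)(C)C)c(=O)c3Cl)o2)c1` is not yet measured. It differs from compound 1 by 3-methylphenyl in place of 2-chlorophenyl on an aromatic carbon. Going by the values given here, the one measured step swaps a different group and does not bear directly on this change; no step of this kind has been measured. The change is therefore expected to give at most a small step, within or near the scatter, and if anything slightly lower. Compound 3 is estimated at 3.05 (range 2.75 to 3.35). The expected step is a number 0.14 log units lower from compound 1 to compound 3 (within the scatter).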

Compound 3, partition coefficient: 3.02
Compound 3: middle estimate off by 0.03 log units, on the high side; low and high end bracket the measured number.
By their numbers in this assay, from the lowest: compounds 2, 3 and 1 (each within the scatter of the next, the first and the last beyond it).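

In this assay 3-methylphenyl in place of 2-chlorophenyl gives a number 0.17 log units lower from compound 1 to compound 3 (within the scatter) and 3-methylphenyl in place of 2,6-difluorophenyl gives a number 0.27 log units higher from compound 2 to compound 3 (within the scatter) at the same aromatic carbon. Compound 3 therefore cannot be told apart from either compound 1 or compound 2, although those two differ beyond the scatter, so a methyl-bearing phenyl here reads the same as both halogen-bearing phenyls within the scatter. No supporting evidence bears on this result.

Open, going by these compounds, is how this position reads with an amine or a carboxylic acid on the phenyl ring. Also open, on these data alone, is whether a longer chain in place of the methyl group would stay within the scatter.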